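From cyclopropyl to isopropyl on the shared core

This account rests on a few compounds, and the source may have more. Where it says the series, first, only, none or still open, it means among the compounds named here.

Measured in an ADME assay on microsomes from liver (Homo sapiens) for metabolic stability; a higher number here means faster removal of the compound, a lower number slower removal:
- compound 1 `CC(=O)N1CC(Oc2cc(-c3cnnc4c3ncn4C(C)C)ccc2F)C1`: < 8 mL.min-1.g-1 (a limit)
- compound 2 `CC(C)n1cnc2c(-c3ccc(F)c(Oc4ccc(C#N)cn4)c3)cnnc21`: 38 mL.min-1.g-1
- compound 3 `Cc1cc(-c2cc(-c3cnnc4c3ncn4C3CC3)ccc2F)ccn1`: 42 mL.min-1.g-1

Compound 3 gives 42 mL.min-1.g-1 in this assay, within the scatter of compound 2 at 38 mL.min-1.g-1. Compound 1 reports only a limit, < 8 mL.min-1.g-1.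

Compound 4 `Cc1cc(-c2cc(-c3cnnc4c3ncn4C(C)C)ccc2F)ccn1` puts isopropyl in place of cyclopropyl on an aromatic nitrogen. For the measured compounds named here, the only measured step, an at least 4.7-fold higher number from compound 1 to compound 2 (0.67 log units; beyond the scatter), keeps isopropyl throughout, so it bears on this exchange only indirectly, and no measured step makes the exchange itself. A change beyond the scatter is therefore not expected, and the estimated step is a 1.1-fold higher number from compound 3 to compound 4 (0.06 log units; within the scatter). For compound 4 the expected value is 48 mL.min-1.g-1, with an estimated range of 24 mL.min-1.g-1 to 95 mL.min-1.g-1.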

Compound 4, intrinsic clearance in microsomes in the Homo sapiens assay: 102 mL.min-1.g-1
Compound 4: the middle estimate sits 2.1-fold (0.33 log units) below what was measured, and the stated range ends below it.
By their numbers in the Homo sapiens assay, from the lowest: compounds 2 and 3 (each within the scatter of the next); then compound 4. At a limit, below all of these: compound 1.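

In the Homo sapiens assay the aromatic nitrogen proves sensitive to an exchange that removes the ring but keeps the three carbons, with a 2.4-fold higher number from compound 3 to compound 4 (0.39 log units; beyond the scatter). In a physicochemical assay for lipophilicity (a higher number here means a more lipophilic compound, a lower number a more polar compound), compound 3 gives 2.9 and compound 4 gives 3.1. In the physicochemical assay the same exchange gives a number 0.20 log units higher from compound 3 to compound 4 (within the scatter). With isopropyl held, the Homo sapiens assay also shows a 2.7-fold higher number from compound 2 to compound 4 (0.43 log units; beyond the scatter) and, resting on a limit for compound 1, an at least 12-fold higher number from compound 1 to compound 4 (1.10 log units; beyond the scatter). Nothing measured here accounts for the step on the nitrogen.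

The compounds shown leave open whether cyclobutyl or tert-butyl on this nitrogen would track cyclopropyl or isopropyl. They also leave open whether the exchange keeps its size with (5-cyanopyridin-2-yl)oxy or (1-acetylazetidin-3-yl)oxy in place of 2-methylpyridin-4-yl.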